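A few compounds are considered here, and "the series" means these few. Any claim that something is new, unique, unknown or untested is made for them only; others in the source may bear on it.

In an ADME assay on BJ cells (Homo sapiens) for cytotoxicity, read by MTT assay, with a stated time of 72 h (a lower number here means a stronger inhibitor, a higher number a weaker inhibitor), compound 1 `COc1ccc(CNc2ncnc3c2ncn3C2CCCCO2)cc1OC` gives only a limit, > 100000 nM. Compound 2 `COc1ccc(CNc2ncnc3c2ncn3C2CCCCO2)c(OC)c1OC` likewise gives only a limit in this assay, > 37500 nM. The change between them, (methoxy in place of hydrogen on an aromatic carbon), yields a step that the two limits leave unreadable from compound 1 to compound 2, since the limit of > 100000 nM in this assay, at which 2 of the 3 values shown sit, and the limit of > 37500 nM in this assay, at which 1 of the 3 values shown sits, are both limits rather than numbers. Compound 3 `COc1cc(CNc2ncnc3c2ncn3C2CCCO2)cc(OC)c1` also gives only a limit in this assay, > 100000 nM. The difference between the core of compound 3 and the core of compound 1 is not broken down here. Compound 4 `COc1cc(CNc2ncnc3c2ncn3C2CCCO2)cc(OC)c1OC` carries the same kind of change, (methoxy in place of hydrogen on an aromatic carbon), though here the methoxy sits ortho to two methoxy groups and para to a large group, whereas in compound 2 it sits ortho to a large group, ortho to a methoxy group and meta to a methoxy group. Compound 4 is expected to show a step of a number no higher from compound 3 to compound 4 (the limit leaves the size open) in this assay, resting on compound 3 giving > 100000 nM. Compound 4 is thus estimated at 100000 nM, between 40000 nM and 300000 nM, most likely again only a limit.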

Compound 4, half-maximal inhibitory concentration: > 100000 nM
Compound 4: a limit, no number; the forecaster's own chance of this, stated with the estimate: 85%; the middle value lies on the limit itself.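

Compound 3 and compound 4 both give only limits in this assay, and the step between them cannot be read. The compounds shown leave open whether methoxy in place of hydrogen on an aromatic carbon shifts the result in this assay at all.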